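The source may hold more compounds than are shown below. What is called first, only, known or untested is meant among the compounds shown, and "the series" means these compounds.

Measured so far in a functional assay on L02 cells (Homo sapiens) for inhibition, read by MTT assay, with a stated time of 48 h; a lower number here means a stronger inhibitor, a higher number a weaker inhibitor:

Compound 1 `COc1ccc2c(=O)c(/C=C/C(=O)Nc3ccccc3)coc2c1` — compound 1 gives > 200000 nM, which is a limit of the assay and not a number.
Compound 2 `O=C(/C=C/c1coc2cc(O)ccc2c1=O)NCc1ccc(F)cc1` — compound 2 gives > 200000 nM, also a limit.
Compound 3 `Cc1ccccc1NC(=O)/C=C/c1coc2cc(O)ccc2c1=O` — compound 3 gives > 200000 nM, again a limit.

Compound 3 therefore stands at the same place as everything else measured here: at the top of the assay, with no real number attached (the limit of > 200000 nM in this assay, at which 3 of the 3 values shown sit). Going by the values given here, the only single-point step among the measured compounds, a step that the two limits leave unreadable from compound 2 to compound 3, has a limit at both of its ends and cannot be read for size or direction.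

The next compound, compound 4 `O=C(/C=C/c1coc2cc(O)ccc2c1=O)Nc1ccccc1`, differs from compound 3 by hydrogen in place of methyl on an aromatic carbon. Among the compounds with values here, no measured step bears on this change in a readable way, so the measured compounds offer no basis for expecting a step in this assay in either direction beyond the scatter; the one thing they do show is that all three sit at the limit (the limit of > 200000 nM in this assay, at which 3 of the 3 values shown sit). Compound 4 is accordingly expected to give 300000 nM, within 100000 nM to 1000000 nM. The step from compound 3 to compound 4 is thus estimated as a step that the limit leaves unreadable from compound 3 to compound 4, with the result most likely reported again only as a limit.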

Compound 4, half-maximal inhibitory concentration: > 200000 nM
Compound 4 gave a limit, no number; the forecaster's own chance of this, stated with the estimate: 85%; the middle value does not contradict the limit.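

In this assay compound 4 gives > 200000 nM, which is a limit and not a number. Its steps from compound 1, compound 2 and compound 3 cannot be read, as all four compounds share one ceiling: the limit of > 200000 nM in this assay, at which 4 of the 4 values shown sit.

The compounds shown leave open whether any of these changes alters inhibition at all.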